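This account rests on a few compounds, and the source may have more. Where it says the series, first, only, none or still open, it means among the compounds named here.

Measured compounds in a functional assay on LNCaP cells (Homo sapiens) for antiproliferative activity, read by propidium iodide staining, with a stated time of 96 h; a higher number here means a weaker inhibitor, a lower number a stronger inhibitor:
Compound 1 `CC(O)(COc1ccc(OC(F)(F)F)cc1)C(=O)Nc1ccc(S(F)(F)(F)(F)F)cc1` gives 18600 nM.
Compound 2 `CC(O)(COc1ccc(C#N)cc1)C(=O)Nc1ccc(S(F)(F)(F)(F)F)cc1` gives 100000 nM.
Compound 3 `CC(O)(COc1ccc(OC(F)(F)F)cc1)C(=O)Nc1cccc(S(F)(F)(F)(F)F)c1` gives 12700 nM.

Compound 1 and compound 3 share the same atoms joined differently; the difference between the two cores is not broken down here. Their two numbers lie within the scatter of each other. The change made on the core of compound 1 is cyano in place of trifluoromethoxy on an aromatic carbon, and it gave a 5.4-fold higher number from compound 1 to compound 2 (0.73 log units; beyond the scatter), a modest step beyond the scatter.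

Compound 4 `CC(O)(COc1ccc(C#N)cc1)C(=O)Nc1cccc(S(F)(F)(F)(F)F)c1` is not yet measured. It carries the same change on the core of compound 3: cyano in place of trifluoromethoxy on an aromatic carbon. The place lines agree word for word, so this is the same change, occurring twice in all among the compounds here. Among the measured compounds shown here, only one earlier instance exists, so it serves as the sole guide. For the measured compounds named here, the expected step is a 5.1-fold higher number from compound 3 to compound 4 (0.71 log units; beyond the scatter), estimated from the one measured step, a 5.4-fold higher number from compound 1 to compound 2 (0.73 log units; beyond the scatter), applied to compound 3 at 12700 nM. Compound 4 is therefore expected near 65000 nM, estimated to fall between 30000 nM and 150000 nM. Compound 2 at 100000 nM shows this change can push a number to the high end of the measured range, so a weak result is possible for compound 4.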

Compound 4, half-maximal inhibitory concentration: 30000 nM
The estimate for compound 4 lay 2.2-fold (0.34 log units) above the measured number, within the range that was stated.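

On a second core, cyano in place of trifluoromethoxy on an aromatic carbon again gives a 2.4-fold higher number from compound 3 to compound 4 (0.37 log units; beyond the scatter) in this assay. The two steps run in the same direction, and their sizes cannot be told apart: the same change on two cores in this assay, a 5.4-fold higher number (0.73 log units; beyond the scatter) from compound 1 to compound 2 and a 2.4-fold higher number (0.37 log units; beyond the scatter) from compound 3 to compound 4, 2.3-fold (0.36 log units) apart, within the scatter of two such steps.
On these two cores, the change therefore carries over in direction and, within the scatter, in size, but this rests on a single comparison and shows neither why the number rises nor whether the step would hold on a further core.

At this place on the ring, only trifluoromethoxy and cyano are shown, which leaves open how an amine or a carboxylic acid would read on either core. Also open, going by these compounds, is whether a longer chain in the linker would shift the numbers, given that all four compounds share the same linker.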